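The source may report more compounds than this note shows. Statements on the series, on what has been measured and on what is new or still open speak of the compounds shown alone.

Measured so far in a physicochemical assay for lipophilicity; on this read-out lower numbers stand for lower lipophilicity and higher numbers for higher lipophilicity:
compound 1 `COc1ccc(C2=NO[C@]3(C2)C(=O)O[C@@H]2[C@H]3CC[C@H](C)[C@]3(O)C=CC(=O)[C@@]23C)cc1`: 1.47
compound 2 `C[C@H]1CC[C@@H]2[C@@H](OC(=O)[C@]23CC(c2ccccc2)=NO3)[C@]2(C)C(=O)C=C[C@@]12O`: 1.41

In this assay, compound 2 gives 1.41, which lies within the scatter of the value for compound 1. The next compound in view is compound 3 `C[C@H]1CC[C@@H]2[C@@H](OC(=O)[C@]23CC(c2ccc(O)cc2)=NO3)[C@]2(C)C(=O)C=C[C@@]12O`, and the change leading to it is hydroxy in place of hydrogen on an aromatic carbon. In words, this is hydroxy in place of hydrogen on an aromatic carbon, or phenyl to 4-hydroxyphenyl.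

For the measured compounds named here, only one measured step bears on this change: a number 0.06 log units lower from compound 1 to compound 2 (within the scatter). That step lies within the scatter. It exchanges methoxy and hydrogen on an aromatic carbon, so it sets no size for a change involving hydroxy. Going by the values given here, no measured compound carries a hydroxy on this ring, and the expectation therefore rests mainly on the structural change itself. A downward step beyond the scatter is expected in this assay, with a wide range. The estimated step is a number 0.51 log units lower from compound 2 to compound 3 (beyond the scatter). The estimate for compound 3 is 0.9, with an expected range of 0.5 to 1.3.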

Compound 3, partition coefficient: 0.932
The estimate for compound 3 lay 0.03 log units below the measured number; the range from low to high includes it.
By their numbers in this assay, from the lowest: compound 3; then compounds 2 and 1 (each within the scatter of the next).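

In this assay, for the compounds shown here, hydroxy in place of hydrogen on this aromatic carbon, para to a large group, gives the first step beyond the scatter at this position: a number 0.48 log units lower from compound 2 to compound 3 (beyond the scatter). Hydrogen in place of the methyl on the oxygen points the same way, a number 0.54 log units lower from compound 1 to compound 3 (beyond the scatter), whereas the exchange of methoxy for hydrogen at the same carbon gave only a number 0.06 log units lower from compound 1 to compound 2 (within the scatter), so among these three compounds the read-out separates the free hydroxy from both hydrogen and methoxy, not the presence of an oxygen on the ring as such. No measurement bears on the reason for this separation.

The compounds shown leave open whether an amine or a carboxylic acid on the same aromatic carbon would give a step of similar size in this assay, or whether the step belongs to hydroxy alone. As far as these compounds go, it also remains open whether a hydroxymethyl group, or a hydroxy on another carbon of this six-membered aromatic ring, would give a read-out closer to compound 3 or to compound 2.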